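The compounds below may be only part of what the source reports. "The series", "measured", "known", "first", "only" and "open" are said of these compounds alone.

Of the compounds shown here, three sharing one core have been read in a functional assay on ECa-109 cells (Homo sapiens) for cytotoxicity, read by MTT assay, with a stated time of 72 h; on this read-out higher numbers stand for weaker inhibition and lower numbers for stronger inhibition. In this assay compound 1 (`O=C1C(=Cc2ccc(O)cc2)C(=O)N(c2ccc(Cl)cc2)N1c1ccc(Cl)cc1`) gives 34200 nM and compound 2 (`COc1cc(C=C2C(=O)N(c3ccc(Cl)cc3)N(c3ccc(Cl)cc3)C2=O)ccc1O`) gives 7100 nM, with a 4.8-fold lower number from compound 1 to compound 2 (0.68 log units; beyond the scatter). Compound 3 (`COc1ccc(C=C2C(=O)N(c3ccc(Cl)cc3)N(c3ccc(Cl)cc3)C2=O)cc1`) gives > 128000 nM, which is a limit of the assay and not a number. Among the compounds with values here, it is the only such reading in the set: the limit of > 128000 nM in this assay, at which 1 of the 3 values shown sits.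

Compound 4 (`O=C1C(=Cc2cccc(Cl)c2)C(=O)N(c2ccc(Cl)cc2)N1c1ccc(Cl)cc1`) departs from compound 3 in one place, (3-chlorophenyl in place of 4-methoxyphenyl on a double-bonded chain carbon bound to a double-bonded ring carbon). Within the data shown here, no measured compound carries the 3-chlorophenyl group, so the measured steps bear on this change only indirectly. Compound 1 and compound 2 carry a hydroxy group on that ring, while compound 3 does not. The steps that remove it are sizeable: an at least 3.7-fold higher number from compound 1 to compound 3 (0.57 log units; beyond the scatter) and an at least 18-fold higher number from compound 2 to compound 3 (1.25 log units; beyond the scatter). Compound 4 has no hydroxy group there either, so it is expected to sit with compound 3 at the weak end, not near compound 2. Any step is expected to be modest and towards a lower number, and a second limit reading remains quite possible. The estimate amounts to an at least 2.1-fold lower number from compound 3 to compound 4 (0.32 log units; beyond the scatter). In this assay compound 4 is expected at 60000 nM, within an estimated range of 16000 nM to 128000 nM.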

Compound 4, half-maximal inhibitory concentration: 22600 nM
Estimate against measurement, compound 4: 2.7-fold (0.42 log units) above; the range from low to high includes it.
By their numbers in this assay, from the lowest: compound 2; then compounds 4 and 1 (each within the scatter of the next). At a limit, above all of these: compound 3.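

In this assay, 3-chlorophenyl in place of 4-methoxyphenyl on the double-bonded chain carbon gives an at least 5.6-fold lower number from compound 3 to compound 4 (0.75 log units; beyond the scatter), so compound 4 shows that a ring without a hydroxy group need not sit at the weak end of the set, which compound 3 alone had suggested. Set against the rings that carry a hydroxy group, the same position gives a 1.5-fold lower number from compound 1 to compound 4 (0.18 log units; within the scatter), which leaves compound 4 and compound 1 within the scatter of each other, and a 3.2-fold higher number from compound 2 to compound 4 (0.50 log units; beyond the scatter), so 3-chlorophenyl matches the 4-hydroxyphenyl ring but not the 4-hydroxy-3-methoxyphenyl ring. The true size of the step from compound 3 stays unknown because that compound's reading is a limit of the assay and not a number: the limit of > 128000 nM in this assay, at which 1 of the 4 values shown sits.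

The compounds shown leave open whether the change in reading follows from the loss of the methoxy group, the arrival of the chlorine, or where each group stands on the ring, and a plain phenyl ring or a 3-methoxyphenyl ring would help to separate these. They also leave open how this position would respond to an amine or a carboxylic acid on the ring.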